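Trimming the piperazine substituent in a xanthine sulfonamide series

The compounds below may be only part of what the source reports. "The series", "measured", "known", "first", "only" and "open" are said of these compounds alone.

Compound 2 `CCCn1c(=O)[nH]c2nc(-c3ccc(S(=O)(=O)N4CCN(c5ccc(Br)cc5)CC4)cc3)[nH]c2c1=O` sits at a limit of the assay rather than at a number: in an assay on CHO cells for displacement of a labelled ligand from adenosine receptor A1 (Homo sapiens), read by scintillation counting, with a stated time of 90 min, in the presence of a further agent that is not named here (a lower number here means a stronger inhibitor, a higher number a weaker inhibitor), compound 2 gives > 1000 nM. Compound 1 `CCCn1c(=O)[nH]c2nc(-c3ccc(S(=O)(=O)N4CCN(c5ccc(F)cc5)CC4)cc3)[nH]c2c1=O` likewise reaches only a limit in this assay, where compound 1 gives > 1000 nM. Within the data shown here, the one step measured so far, a step that the two limits leave unreadable from compound 1 to compound 2, cannot be read because both ends rest on (the limit of > 1000 nM in this assay, at which 2 of the 2 values shown sit). Compound 3 `CCCn1c(=O)[nH]c2nc(-c3ccc(S(=O)(=O)N4CCN(C)CC4)cc3)[nH]c2c1=O` differs from compound 2 by methyl in place of 4-bromophenyl on an amine nitrogen in a ring. Among the measured compounds shown here, no measured step touches this change, so the two limits offer a floor on weakness and no direction. The expectation for compound 3 is therefore a step that the limit leaves unreadable from compound 2 to compound 3 in this assay, with the limit again the most likely outcome. Compound 3 is estimated at 2000 nM in this assay, within a range from 400 nM to 10000 nM.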

Compound 3, inhibition constant: 334 nM
Compound 3: middle estimate off by 6.0-fold (0.78 log units), on the high side; the measured number lies below the stated range.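

In this assay, methyl in place of 4-bromophenyl on the amine nitrogen in the ring gives an at least 2.9-fold lower number from compound 2 to compound 3 (0.47 log units; beyond the scatter), and methyl in place of 4-fluorophenyl at the same place gives an at least 2.9-fold lower number from compound 1 to compound 3 (0.47 log units; beyond the scatter). This gives the position its first direction: among the three compounds shown, only compound 3, with the aromatic ring gone from this nitrogen, reaches a measured number. Both steps give only a minimum size, and the step between the two aryl compounds cannot be read, because those compounds rest on a limit: the limit of > 1000 nM in this assay, at which 2 of the 3 values shown sit.

On these data alone, what remains open is whether the lower number depends on methyl itself or simply on the loss of the aryl group. Ethyl, a longer chain, benzyl or a plain hydrogen on this nitrogen could each help to separate these two readings.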